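Pyridylmethyl-amine arm in place of oxanyl-amine chain

The compounds below may be only part of what the source reports. "The series", "measured", "known", "first", "only" and "open" are said of these compounds alone.

Compound 1 `c1ccc2c(c1)CN[C@@H](CN(CCCCN(Cc1ccncc1)Cc1ccncc1)[C@H]1CCCc3cccnc31)C2` and compound 2 `c1ccc2c(c1)CN[C@@H](CN(CCCCNC1CCOCC1)[C@H]1CCCc3cccnc31)C2` share a core and differ only in the amine arm. In a functional assay on cells for agonist activity at C-X-C chemokine receptor type 4 (Homo sapiens), read by fluorescence and calcium flux, with a stated time of 90 s (a higher number here means that more compound is needed for the effect, a lower number that less compound is needed), compound 1 gives > 30000 nM, a limit of the assay. In this assay, compound 2 gives > 30000 nM, likewise a limit and not a number. Among the measured compounds shown here, both values sit at the limit of > 30000 nM in this assay, at which 2 of the 2 values shown sit, so no order between the two compounds can be drawn, and no measured step exists.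

Compound 3 `C(=C/CN(C[C@H]1Cc2ccccc2CN1)[C@H]1CCCc2cccnc21)\CNCc1cccnc1` is not yet measured. Its change from compound 2 is a group of 11 heavy atoms (9 carbon, 2 nitrogen; one six-membered aromatic ring with 1 hetero atom) in place of a group of 10 heavy atoms (8 carbon, 1 nitrogen, 1 oxygen; one six-membered non-aromatic ring with 1 hetero atom), on a saturated chain carbon bound to an amine nitrogen, the entering group carrying one double bond outside aromatic rings and one six-membered aromatic ring with one hetero atom. With compound 2 at a limit, no step beyond the scatter is expected, and compound 3 is estimated at 25000 nM (range 5000 nM to 60000 nM), which would mean a step of an at least 1.2-fold lower number from compound 2 to compound 3 (0.07 log units; that floor lies within the scatter), with a fair chance that only a limit is reported again.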

Compound 3, half-maximal effective concentration: > 30000 nM
Compound 3 ended at the assay's limit; the forecaster's own chance of this, stated with the estimate: 60%; at least 1.2-fold (0.07 log units) between middle value and limit.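

In this assay compound 3 gives > 30000 nM, a limit of the assay and not a number; compound 2 also stands at a limit, so no step can be read between compound 2 and compound 3. The compounds shown leave open which amine arm on the shared core, if any, would give a readable value in this assay.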